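A few compounds are considered here, and "the series" means these few. Any claim that something is new, unique, unknown or untested is made for them only; others in the source may bear on it.

Compound 3 `Cc1cn2c(/C=N/NC(=N)N)c(-c3ccccn3)nc2s1` is set against compound 1 `N=C(N)N/N=C/c1c(-c2ccncc2)nc2sc(Cl)cn12` and compound 2 `Cc1sc2nc(-c3ccncc3)c(/C=N/NC(=N)N)n2c1C`. In a functional assay on ovarian cells (Homo sapiens) for antiproliferative activity (on this read-out higher numbers stand for weaker inhibition of growth and lower numbers for stronger inhibition of growth), compound 3 gives 63100 nM, the second highest of the three numbers. Compound 2 gives 97700 nM, which lies within the scatter of the number of compound 3, so no order between the two is claimed. Compound 1 gives 20900 nM, a lower number, and that gap lies beyond the scatter. Compound 4 `Cc1cn2c(/C=N/NC(=N)N)c(-c3ccncc3)nc2s1` awaits measurement in this assay. It differs from compound 3 in one place: pyridin-4-yl in place of pyridin-2-yl on an aromatic carbon. Compound 1 and compound 2 both carry pyridin-4-yl and their numbers bracket that of compound 3, so a change within the scatter is expected. The expected step is a 1.4-fold lower number from compound 3 to compound 4 (0.15 log units; within the scatter). Compound 4 is expected to give 45000 nM, with a range from 15000 nM to 140000 nM.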

Compound 4, concentration for total growth inhibition: 34700 nM
Beside the measured number, compound 4's estimate is 1.3-fold (0.11 log units) above it, within the range that was stated.
By their numbers in this assay, from the lowest: compounds 1, 4, 3 and 2 (each within the scatter of the next, the first and the last beyond it).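

In this assay, pyridin-4-yl in place of pyridin-2-yl on the aromatic carbon gives a 1.8-fold lower number from compound 3 to compound 4 (0.26 log units; within the scatter), so this pair does not separate the two pyridine attachments. Going by these compounds alone, on the other aromatic carbon of the shared core, hydrogen in place of methyl gives a 2.8-fold lower number from compound 2 to compound 4 (0.45 log units; beyond the scatter), the only one of these steps beyond the scatter, while methyl in place of chloro gives a 1.7-fold higher number from compound 1 to compound 4 (0.22 log units; within the scatter). No supporting data bear on these steps. Open, as far as these compounds go, is how pyridin-3-yl or phenyl would read on the first carbon. Also open, from the compounds shown here alone, is how an amine or a longer alkyl chain would read on the second.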